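Removing a Fluorine: Expected Effect on Cell Growth Inhibition

A few compounds are considered here, and "the series" means these few. Any claim that something is new, unique, unknown or untested is made for them only; others in the source may bear on it.

Of the compounds shown here, three sharing one core have been tested in a functional assay on NCI-H460 cells (Homo sapiens) for antiproliferative activity, read by MTT assay, with a stated time of 48 h; on this read-out higher numbers stand for weaker inhibition and lower numbers for stronger inhibition. Compound 1 `CC1(C)Cc2c(ccc(C(=O)/C=C/c3cn(-c4ccccc4)nc3-c3ccc(Cl)cc3)c2OCc2ccccc2)O1` gives > 100000 nM, which is a limit of the assay rather than a number. Compound 3 `Cc1ccc(-c2nn(-c3ccccc3)cc2/C=C/C(=O)c2ccc3c(c2OCc2ccccc2)CC(C)(C)O3)cc1` likewise gives > 100000 nM, again a limit and not a number. That is the limit of > 100000 nM in this assay, at which 2 of the 3 values shown sit. The step from compound 1 to compound 3, a step that the two limits leave unreadable from compound 1 to compound 3, therefore reveals nothing about its size. Among the compounds with values here, compound 2 `CC1(C)Cc2c(OCc3ccccc3)ccc(C(=O)/C=C/c3ccc(F)cc3)c2O1` stands apart: in this assay compound 2 gives 22300 nM, the only actual number among the three.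

Compound 4 `CC1(C)Cc2c(OCc3ccccc3)ccc(C(=O)/C=C/c3ccccc3)c2O1` differs from compound 2 in one place: hydrogen in place of fluoro on an aromatic carbon. Within the data shown here, no measured step concerns this kind of change, and the only measured step cannot be read at all. Among the measured compounds shown here, nothing among the measured compounds therefore points to a step in either direction, and the expectation is for a change no larger than the usual scatter of repeated measurements. Compound 4 is accordingly expected to give about 25000 nM, within a range from 10000 nM to 60000 nM. This estimate means an expected step of a 1.1-fold higher number from compound 2 to compound 4 (0.05 log units; within the scatter), which is expected to stay within the scatter.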

Compound 4, half-maximal inhibitory concentration: > 100000 nM
Compound 4 ended at the assay's limit; the forecaster's own chance of this, stated with the estimate: 15%; at least 4.0-fold (0.60 log units) between middle value and limit.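

In this assay, this place on the ring is not a silent one: going from 4-fluorophenyl to phenyl gives an at least 4.4-fold higher number from compound 2 to compound 4 (0.65 log units; beyond the scatter). Compound 4 gives > 100000 nM, which is a limit of the assay and not a number, so this step has a smallest possible size but no known full size. The only earlier step could not be read, so this is the first step in the series with any readable size, and it ties the one measured number to a single fluoro group, with compound 2 alone giving a number: the limit of > 100000 nM in this assay, at which 3 of the 4 values shown sit.

As far as these compounds go, what an amine, a nitrile or a carboxylic acid would do at this same place on the ring remains open, so it cannot yet be said whether fluoro itself matters or whether other groups there would serve as well. Also open, from the compounds shown here alone, is how far compound 4 really lies from compound 2, and whether a fluoro group would matter as much in compounds that carry the larger groups of compound 1 and compound 3.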